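Urea-nitrogen substituents in an aminothiazole guanidine series

This account rests on a few compounds, and the source may have more. Where it says the series, first, only, none or still open, it means among the compounds named here.

Measured compounds in an assay on membranes from Sf9 cells for displacement of a labelled ligand from histamine H2 receptor (Homo sapiens), read by scintillation counting, with a stated time of 60 min; a higher number here means a weaker inhibitor, a lower number a stronger inhibitor:
compound 1 `Cc1nc(N)sc1CCCN/C(N)=N/C(=O)NCC(C)CCc1ccccc1`, 63.1 nM
compound 2 `CCCNC(=O)/N=C(\N)NCCCc1sc(N)nc1C`, 105 nM
compound 3 `Cc1ccc(CC(C)CNC(=O)/N=C(\N)NCCCc2sc(N)nc2C)cc1`, 72.4 nM

Compound 2 carries a propyl group on the amide-type nitrogen and gives 105 nM; its gaps to the other two compounds, a 1.7-fold higher number from compound 1 to compound 2 (0.22 log units; within the scatter) and a 1.5-fold lower number from compound 2 to compound 3 (0.16 log units; within the scatter), both lie within the scatter. Compound 4 `Cc1nc(N)sc1CCCN/C(N)=N/C(=O)NC1CCCCC1` differs from compound 2 by cyclohexyl in place of propyl on an amide-type nitrogen. Going by the values given here, the steps that bear on this change are a 1.7-fold higher number from compound 1 to compound 2 (0.22 log units; within the scatter) and a 1.5-fold lower number from compound 2 to compound 3 (0.16 log units; within the scatter); neither went beyond the scatter, so no step beyond the scatter is expected here either. The expected step is a 1.3-fold lower number from compound 2 to compound 4 (0.12 log units; within the scatter). Compound 4 is therefore estimated at 80 nM, with a range of 35 nM to 200 nM.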

Compound 4, inhibition constant: 170 nM
Compound 4: middle estimate off by 2.1-fold (0.33 log units), on the low side, and the stated range covers the measured number.
By their numbers in this assay, from the lowest: compounds 1, 3, 2 and 4 (each within the scatter of the next, the first and the last beyond it).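

Among the compounds shown, only compound 4 has a ring on the amide-type nitrogen, and exchanging propyl for cyclohexyl gives a 1.6-fold higher number from compound 2 to compound 4 (0.21 log units; within the scatter) in this assay. This position therefore takes a six-membered non-aromatic ring of carbon only, in place of an open chain, without a step beyond the scatter. Nothing available explains how the ring and the chain compare here. 

Still open, on these data alone, is whether an amine or a carboxylic acid carried on the cyclohexyl ring would give a step beyond the scatter. A phenyl group on this nitrogen also remains to be compared with cyclohexyl.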